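This account rests on a few compounds, and the source may have more. Where it says the series, first, only, none or still open, it means among the compounds named here.

In an ADME assay on HCT-116 cells (Homo sapiens) for cytotoxicity, read by CellTiter-Glo, with a stated time of 72 h (a lower number here means a stronger inhibitor, a higher number a weaker inhibitor), compound 1 `Cc1cc(C)c(S(=O)(=O)N2CCC(N3CCC(C)CC3)CC2)c(C)c1` gives > 5000 nM, which is a limit of the assay. Compound 2 `Cc1ccc(-c2ccccc2S(=O)(=O)N2CCC(N3CCC(C)CC3)CC2)cc1` gives > 5000 nM, which is also a limit. Compound 3 `CC1CCN(C2CCN(S(=O)(=O)c3cccc4ccccc34)CC2)CC1` gives > 10000 nM, again a limit. All three readings are limits, so compound 2 stands with no numerical value and cannot be ranked against the other two.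

The next compound, compound 4 `CC1CCN(C2CCN(S(=O)(=O)c3ccccc3Br)CC2)CC1`, changes compound 2 as follows: bromo in place of 4-methylphenyl on an aromatic carbon. This puts bromo in place of 4-methylphenyl on an aromatic carbon of a six-membered aromatic ring of carbon only, ortho to a large group.

Going by the values given here, no measured step gives a size for this change. No shift beyond the scatter is expected in this assay, and the estimated move is a step that the limit leaves unreadable from compound 2 to compound 4. This expectation rests on compound 3, whose reading of > 10000 nM is a limit, and a further limit is the likely report. For compound 4 the expected value is 8000 nM, with an estimated range of 3000 nM to 20000 nM.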

Compound 4, half-maximal inhibitory concentration: > 5000 nM
Compound 4: no number, only a limit (the forecaster's own chance of this, stated with the estimate: 80%); the middle value lies beyond the limit too.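

Going by these compounds alone, no step between compound 2 and compound 4 can be read in this assay, since both readings are limits of the assay. The compounds shown leave open whether any replacement at this place gives a numerical reading, and how far the series stands from the limits.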